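A Substituted Phenyl Ring on the Core Nitrogen

This account rests on a few compounds, and the source may have more. Where it says the series, first, only, none or still open, it means among the compounds named here.

Measured compounds:
compound 1 `CNC(=O)c1cc(Oc2ccc(NC(=O)c3cc4cccnc4n(-c4ccccc4)c3=O)cc2)ccn1` — 250 nM
compound 2 `CNC(=O)c1cc(Oc2ccc(NC(=O)c3cc4cccnc4n(-c4ccc(OC)cc4)c3=O)cc2)ccn1` — 920 nM

In a functional assay on HT-29 cells (Homo sapiens) for antiproliferative activity, read by MTT assay, with a stated time of 72 h (on this read-out lower numbers stand for stronger inhibition and higher numbers for weaker inhibition), compound 1 gives 250 nM, the lowest of the two numbers, while compound 2 gives 920 nM. Among the compounds with values here, the only measured step, a 3.7-fold higher number from compound 1 to compound 2 (0.57 log units; beyond the scatter), comes from methoxy in place of hydrogen on an aromatic carbon of the phenyl ring. Compound 3 `CNC(=O)c1cc(Oc2ccc(NC(=O)c3cc4cccnc4n(-c4ccc(C(F)(F)F)cc4Cl)c3=O)cc2)ccn1` is defined by 2-chloro-4-(trifluoromethyl)phenyl in place of phenyl on an aromatic nitrogen. This change also substitutes that ring, so a weakening of similar or somewhat larger size in this assay is expected. Compound 3 is estimated at 900 nM, within 250 nM to 3200 nM. The expected step is a 3.6-fold higher number from compound 1 to compound 3 (0.56 log units; beyond the scatter).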

Compound 3, half-maximal inhibitory concentration: 3190 nM
Compound 3: middle estimate off by 3.5-fold (0.55 log units), on the low side; low and high end bracket the measured number.
By their numbers in this assay, from the lowest: compound 1; then compound 2; then compound 3.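

In this assay, the change on the core nitrogen can cost more than the methoxy step suggested: 2-chloro-4-(trifluoromethyl)phenyl gives a 13-fold higher number from compound 1 to compound 3 (1.11 log units; beyond the scatter), and it also falls behind 4-methoxyphenyl, with a 3.5-fold higher number from compound 2 to compound 3 (0.54 log units; beyond the scatter). Both substituted rings shown therefore rank behind plain phenyl, by different amounts. Nothing available explains the difference between these rings.

The compounds shown do not separate the chlorine from the trifluoromethyl, which enter together. Going by these compounds, whether an amine or a carboxylic acid on this ring would match compound 1 also stays open.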